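The compounds below may be only part of what the source reports. "The series", "measured", "known", "first", "only" and "open" are said of these compounds alone.

Measured so far in a toxicity assay on MDCK cells (Canis lupus familiaris) for cytotoxicity, read by crystal violet staining, with a stated time of 48 h; a higher number here means that more compound is tolerated, a lower number that less compound is tolerated:
compound 1 `Cc1ccc2[nH]c(=O)c(CN(Cc3ccc(O)cc3)Cc3ccc(C(C)(C)C)cc3)cc2c1` gives 4900 nM
compound 2 `Cc1ccc2[nH]c(=O)c(CN(Cc3ccc(OCCO)cc3)Cc3ccc(C(C)(C)C)cc3)cc2c1` gives > 5000 nM
compound 3 `Cc1ccc2[nH]c(=O)c(CN(Cc3ccc(SC(F)F)cc3)Cc3ccc(C(C)(C)C)cc3)cc2c1` gives > 5000 nM

Compound 3 stands at a limit of this assay rather than at a number, as the limit of > 5000 nM in this assay, at which 2 of the 3 values shown sit, records. Compound 2 likewise sits at a limit. The step of an at least 1.0-fold higher number from compound 1 to compound 3 (0.00 log units; that floor lies within the scatter) stays within the scatter, and a step that the two limits leave unreadable from compound 2 to compound 3. Compound 4 `COc1ccc(C(C)N(Cc2ccc(C(C)(C)C)cc2)Cc2cc3cc(C)ccc3[nH]c2=O)cc1` differs from compound 3 in one place: 1-(4-methoxyphenyl)ethyl in place of 4-((difluoromethyl)sulfanyl)benzyl on an amine nitrogen. Within the data shown here, no measured step exchanges this whole group; the steps that vary it, an at least 1.0-fold higher number from compound 1 to compound 2 (0.00 log units; that floor lies within the scatter) and an at least 1.0-fold higher number from compound 1 to compound 3 (0.00 log units; that floor lies within the scatter), remained within the scatter. Compound 4 is therefore expected to show a number no higher from compound 3 to compound 4 (the limit leaves the size open), no change beyond the scatter. The estimate for compound 4 is 5000 nM, with a range from 2500 nM to 10000 nM, and quite possibly again only a limit.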

Compound 4, half-maximal cytotoxic concentration: > 5000 nM
Compound 4: only a limit was reported (the forecaster's own chance of this, stated with the estimate: 60%); the middle value lies on the limit itself.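

Compound 4 also ends at a limit in this assay, so the exchange of the whole group on the amine nitrogen for 1-(4-methoxyphenyl)ethyl brings no readable drop. Among these compounds, the only readable step, an at least 1.0-fold higher number from compound 1 to compound 4 (0.00 log units; that floor lies within the scatter), stays within the scatter, while the steps from compound 2 and from compound 3 to compound 4 cannot be read. The series now gathers at one end of the assay's range: the limit of > 5000 nM in this assay, at which 3 of the 4 values shown sit.

From the compounds shown here alone, how far compound 2, compound 3 and compound 4 lie past that limit remains open. So does whether a carboxylic acid or an amine in place of 1-(4-methoxyphenyl)ethyl would give a readable number.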